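The compounds below may be only part of what the source reports. "The series", "measured", "known", "first", "only" and "open" are said of these compounds alone.

Measured so far in a functional assay on HCT-116 cells (Homo sapiens) for antiproliferative activity, read by MTT assay, with a stated time of 24 h; on this read-out lower numbers stand for stronger inhibition and higher numbers for weaker inhibition:
compound 1 `COc1ccc(/C=C/C(=O)c2ccc(OC)c3c2OC(C)(C)C=C3)c(F)c1` — > 10000 nM
compound 2 `COc1ccc(C(=O)/C=C/c2ccc3ccccc3c2)c2c1C=CC(C)(C)O2` — 5820 nM
compound 3 `COc1ccc(C(=O)/C=C/c2ccc(Cl)c(Cl)c2)c2c1C=CC(C)(C)O2` — 9440 nM

The value of compound 1 in this assay is a limit of the assay, not a number, and compound 1 therefore sits at the limit of > 10000 nM in this assay, at which 1 of the 3 values shown sits. Compound 2 and compound 3 both give numbers, and both lie in the weak range of this assay.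

The piece follows the step from compound 1 to compound 4 `COc1ccc(C(=O)/C=C/c2ccc(O)c(Br)c2)c2c1C=CC(C)(C)O2`, which has not yet been measured. Compound 4 differs from compound 1 in one place: 3-bromo-4-hydroxyphenyl in place of 2-fluoro-4-methoxyphenyl on a double-bonded chain carbon bound to a double-bonded chain carbon.

One measured step changes the same place, the group on a double-bonded chain carbon bound to a double-bonded chain carbon: an at least 1.0-fold lower number from compound 1 to compound 3 (0.02 log units; that floor lies within the scatter). Compound 2 also carries a different group at that place, and its value lies in the same weak region as that of compound 3. Swapping the group at this place has so far produced no step beyond the scatter, so no step beyond the scatter is expected for compound 4 either, and a value near the limit remains possible.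

Compound 4 is therefore estimated at 9000 nM, in the range 4000 nM to 20000 nM, which means an expected step of an at least 1.1-fold lower number from compound 1 to compound 4 (0.04 log units; that floor lies within the scatter).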

Compound 4, half-maximal inhibitory concentration: > 10000 nM
Compound 4: only a limit was reported; the forecaster's own chance of this, stated with the estimate: 45%; middle value at least 1.1-fold (0.04 log units) from the limit.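

In this assay compound 4 gives > 10000 nM, which is a limit of the assay and not a number. Against 3,4-dichlorophenyl, the swap to 3-bromo-4-hydroxyphenyl gives an at least 1.0-fold higher number from compound 3 to compound 4 (0.02 log units; that floor lies within the scatter), while the step from compound 1 to compound 4 cannot be read, as both of its ends are limits. The new group adds a hydrogen-bond donor at this place on the chain, which 2-fluoro-4-methoxyphenyl does not carry, yet compound 4 shows no sign of stronger inhibition, and the same limit now recurs among the compounds shown: the limit of > 10000 nM in this assay, at which 2 of the 4 values shown sit.

The compounds shown leave open how far past the limit compound 1 and compound 4 lie, and whether any group at this place can move the number by more than the scatter. A phenyl ring carrying an amine or a carboxylic acid, or a longer chain at this place, would test that question with a kind of group not yet among these compounds.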